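This account rests on a few compounds, and the source may have more. Where it says the series, first, only, none or still open, it means among the compounds named here.

Measured in this series:

compound 1 `Brc1cccc(COc2nc3ccccc3s2)c1` — 51.9%
compound 2 `FC(F)(F)c1ccc(COc2nc3ccccc3s2)cc1` — 99.6%
compound 3 `O=[N+]([O-])c1ccc(COc2nc3ccccc3s2)cc1` — 97%

In a functional assay on the whole organism with Mus musculus as the target, in the writhing test, at a dose of 100 mg/kg by the intraperitoneal route (a lower number here means less inhibition, a higher number more inhibition at the dose given (going by the name of the read-out)), compound 3 gives 97%, the second highest of the three numbers. Among the compounds with values here, the only step between measured compounds that differ in one place, a number 2.6 percentage points lower from compound 2 to compound 3 (within the scatter), lies within the scatter, so compound 2 and compound 3 cannot be ranked against each other. Within the data shown here, compound 1, with 51.9%, sits far below both, beyond the scatter; no single-point step connects it to compound 3.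

Compound 4 `N#Cc1ccc(COc2nc3ccccc3s2)cc1` is still to be measured. It differs from compound 3 in one place: cyano in place of nitro on an aromatic carbon. Among the measured compounds shown here, the one measured step at this place, the step of a number 2.6 percentage points lower from compound 2 to compound 3 (within the scatter), changed the read-out by an amount inside the scatter. For the measured compounds named here, no step exchanges nitro for cyano, so the expectation rests only on that one step. The step of a number 5 percentage points lower from compound 3 to compound 4 (within the scatter) is therefore expected to stay within the scatter, with the high read-out kept. Compound 4 is estimated at 92%, in the range 70% to 100%.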

Compound 4, a percentage reported as inhibition, in the whole organism at one dose (the size of the read-out at that dose, not a potency): "not active" (no number reported)
For compound 4 the study gives words and no number, so the estimate cannot be set against anything.
By their numbers in this assay, from the lowest: compound 1; then compounds 3 and 2 (each within the scatter of the next).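

Within the data shown here, compound 4 is reported only in words, as not active, so no step from compound 3 to compound 4 can be read. Nothing shown bears on this result. The compounds shown leave open how large the change from nitro to cyano is in this read-out.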